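Returning a Substituted Benzyl Group to the Phenol Oxygen

This account rests on a few compounds, and the source may have more. Where it says the series, first, only, none or still open, it means among the compounds named here.

Compound 3 `O=C1CC(c2ccccc2O)Oc2ccccc21` carries a free hydroxyl on its aromatic ring and gives 71300 nM in a functional assay on J774.A1 cells (Mus musculus) for inhibition, read by Griess assay, with stated times of 1 h and 24 h; on this read-out lower numbers stand for stronger inhibition and higher numbers for weaker inhibition. Among the three measured compounds this is the highest number, and the nearest neighbour is compound 2 `C=CCOc1ccccc1C1CC(=O)c2ccccc2O1`, which gives 38600 nM in this assay; the gap between them, a 1.8-fold higher number from compound 2 to compound 3 (0.27 log units; within the scatter), stays within the scatter. The furthest is compound 1 `O=C1CC(c2ccccc2OCc2ccccc2)Oc2ccccc21`, with 23200 nM in this assay, and the step of a 3.1-fold higher number from compound 1 to compound 3 (0.49 log units; beyond the scatter) lies beyond the scatter, so compound 3 is a weaker inhibitor than compound 1. The remaining step, a 1.7-fold higher number from compound 1 to compound 2 (0.22 log units; within the scatter), is within the scatter.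

Compound 4 `O=C1CC(c2ccccc2OCc2cccc(F)c2)Oc2ccccc21` is compound 3 with one change: 3-fluorobenzyl in place of hydrogen on an oxygen on an aromatic ring. This change is the reverse of the step from compound 1 to compound 3, with a fluorine added to the benzyl ring, so the step of a 3.1-fold higher number from compound 1 to compound 3 (0.49 log units; beyond the scatter) is the one that bears on it most directly. The expectation is therefore a lower number, roughly undoing that step, giving a 3.2-fold lower number from compound 3 to compound 4 (0.51 log units; beyond the scatter). Compound 4 is estimated at 22000 nM in this assay, with a range from 9000 nM to 55000 nM, because compound 1 gives 23200 nM and the fluorine is a small addition whose effect cannot be read from these three compounds.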

Compound 4, half-maximal inhibitory concentration: 13200 nM
For compound 4 the middle estimate is 1.7-fold (0.22 log units) above the measured one; low and high end bracket the measured number.
By their numbers in this assay, from the lowest: compounds 4, 1, 2 and 3 (each within the scatter of the next, the first and the last beyond it).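

In this assay, 3-fluorobenzyl in place of hydrogen on the oxygen on the aromatic ring gives a 5.4-fold lower number from compound 3 to compound 4 (0.73 log units; beyond the scatter), which shows that this oxygen accepts a benzyl group carrying a substituent and that the number still falls beyond the scatter relative to the free hydroxyl. Compound 1 and compound 2 could not be told apart, but the new benzyl ether does separate from the allyl ether, with a 2.9-fold lower number from compound 2 to compound 4 (0.47 log units; beyond the scatter), while fluoro in place of hydrogen on an aromatic carbon gives only a 1.8-fold lower number from compound 1 to compound 4 (0.24 log units; within the scatter), so the fluorine itself has no effect that can be told from the usual scatter. Nothing shown here gives a measured reason for any of these differences.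

The compounds shown leave open whether a larger change on the benzyl ring, such as a methoxy group, an amine or a carboxylic acid, would move the number beyond the scatter of compound 1. They also leave open what a longer chain between the oxygen and that ring would do, and how a saturated propyl group would compare with allyl.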